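A few compounds are considered here, and "the series" means these few. Any claim that something is new, unique, unknown or untested is made for them only; others in the source may bear on it.

Measured in an ADME assay on microsomes (Mus musculus) for metabolic stability; a higher number here means that the compound lasts longer, a lower number that the compound disappears faster:
- compound 1 `CC[C@@H]1NC(=O)[C@H](CCCNC(=N)N)NC(=O)[C@](C)(NC(=O)C(C)C)CCCCN(C)C(=O)[C@@H](c2ccc(Cl)cc2)NC1=O`: > 1 h
- compound 2 `CC[C@@H]1NC(=O)[C@H](CCCNC(=N)N)NC(=O)[C@](C)(NC(=O)C(C)C)CCNC(=O)[C@@H](c2ccccc2)NC1=O`: > 1 h

Neither entry is a number. Compound 1 stands at > 1 h, which is a limit of the assay. Compound 2 reads > 1 h, which is likewise a limit. The whole picture so far is the limit of > 1 h in this assay, at which 2 of the 2 values shown sit, so compound 1 can be placed only at that limit and cannot be ranked against compound 2.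

Compound 3 `CC[C@@H]1NC(=O)[C@H](CCCNC(=N)N)NC(=O)[C@](C)(NC(=O)C(C)C)CCCCN(C)C(=O)[C@@H](c2ccc(F)cc2)NC1=O` has not yet been measured in this assay. It keeps the core of compound 1 and changes one substituent: fluoro in place of chloro on an aromatic carbon. In words, this is fluoro in place of chloro on an aromatic carbon, para to a large group, or 4-chlorophenyl to 4-fluorophenyl.

For the measured compounds named here, no measured step covers this change, so the expectation rests on compound 1 with its > 1 h alone. No step beyond the scatter is expected in this assay, and no direction is assumed. The estimated step is a step that the limit leaves unreadable from compound 1 to compound 3. A report of compound 3 as a limit again is the likeliest outcome. As a value, compound 3 is estimated at 1.5 h, with an expected range of 0.8 h to 3 h.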

Compound 3, half-life: > 1 h
Compound 3 gave a limit, no number; the forecaster's own chance of this, stated with the estimate: 75%; the middle value is on the limit's open side.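

In this assay compound 3 gives > 1 h as a limit, not a number. For the compounds shown here, no step between compound 1 and compound 3 can be read, since both entries are limits: the limit of > 1 h in this assay, at which 3 of the 3 values shown sit. The compounds shown leave open how far any of the half-lives lie past that limit, and whether 4-chlorophenyl to 4-fluorophenyl changes the half-life at all.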